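From isopropyl to 4-methylphenyl on an aromatic nitrogen

The compounds below may be only part of what the source reports. "The series", "measured", "known", "first", "only" and "open" are said of these compounds alone.

In a functional assay on HeLa cells (Homo sapiens) for antiproliferative activity, read by MTT assay, with a stated time of 72 h (a lower number here means a stronger inhibitor, a higher number a weaker inhibitor), compound 1 `COc1cc(-c2nccn2C(C)C)cc(OC)c1OC` gives > 100000 nM, which is a limit of the assay and not a number. Compound 1 therefore stands at the limit of > 100000 nM in this assay, at which 1 of the 3 values shown sits.

Two other compounds share the core of compound 1 but carry an aromatic ring on the aromatic nitrogen. Compound 2 `COc1ccc(-n2ccnc2-c2cc(OC)c(OC)c(OC)c2)cc1[N+](=O)[O-]` gives 2500 nM and compound 3 `COc1cc(-c2nccn2-c2ccc3[nH]ccc3c2)cc(OC)c1OC` gives 4400 nM, and these two values lie within the usual scatter of each other.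

The step to compound 4 `COc1cc(-c2nccn2-c2ccc(C)cc2)cc(OC)c1OC` puts 4-methylphenyl in place of isopropyl on an aromatic nitrogen, (4-methylphenyl in place of isopropyl on an aromatic nitrogen), and leaves the rest of compound 1 unchanged. No measured pair of these compounds differs in one place, so the size of this step has not been seen directly.

The expectation rests on the numbers given by compound 2, at 2500 nM, and compound 3, at 4400 nM, whose nitrogen substituents are closer to the incoming group than isopropyl is. A large step towards stronger inhibition is therefore expected in this assay, estimated as an at least 33-fold lower number from compound 1 to compound 4 (1.52 log units; beyond the scatter). For compound 4 the estimated half-maximal inhibitory concentration is 3000 nM, with an expected range from 600 nM to 15000 nM.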

Compound 4, half-maximal inhibitory concentration: 700 nM
Estimate against measurement, compound 4: 4.3-fold (0.63 log units) above, and the stated range covers the measured number.
By their numbers in this assay, from the lowest: compound 4; then compounds 2 and 3 (each within the scatter of the next). At a limit, above all of these: compound 1.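

In this assay, putting 4-methylphenyl in place of isopropyl on an aromatic nitrogen, with the rest of the core of compound 1 unchanged, gives an at least 140-fold lower number from compound 1 to compound 4 (2.15 log units; beyond the scatter). For the compounds shown here, this is the first reading of a change at this position alone, and the incoming group holds carbon only, so a measurable number here does not depend on any nitrogen or oxygen in that group, which compound 2 and compound 3 could not show. The true size of the step remains unknown, since one end of it is a limit of the assay and not a number: the limit of > 100000 nM in this assay, at which 1 of the 4 values shown sits.

The compounds shown leave open whether the aromatic ring alone accounts for this step or whether its methyl group takes part, a question that a plain phenyl group on the same nitrogen would address. They also leave open how an amine or a carboxylic acid on that ring, or a longer alkyl chain on the nitrogen in place of isopropyl, would read in this assay.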